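From Phenethyl to 4-Nitrophenyl: Tolerance in Cells

This account rests on a few compounds, and the source may have more. Where it says the series, first, only, none or still open, it means among the compounds named here.

Three compounds sharing a core have been examined in an ADME assay on MT4 cells (Homo sapiens) for cytotoxicity, read by MTT assay, with a stated time of 3 days; a higher number here means that more compound is tolerated, a lower number that less compound is tolerated. Compound 1 (`CC(C)(C)NC(=O)COC(=O)c1ccc([N+](=O)[O-])o1`) gives > 100000 nM, which is a limit of the assay and not a number. Compound 2 (`O=C(COC(=O)c1ccc([N+](=O)[O-])o1)NC1CCc2ccccc21`) gives > 100000 nM, again a limit. Compound 3 (`CC(C)(C)N(CCCc1ccccc1)C(=O)COC(=O)c1ccc([N+](=O)[O-])o1`) is recorded only as "not active" (no number reported), so it has no number of its own. Compound 4 (`CC(C)(C)N(Cc1ccc([N+](=O)[O-])cc1)C(=O)COC(=O)c1ccc([N+](=O)[O-])o1`) has not yet been measured. The change 4-nitrophenyl in place of phenethyl on a saturated chain carbon bound to an amide-type nitrogen puts 4-nitrophenyl in place of phenethyl on a saturated chain carbon bound to an amide-type nitrogen. Among the measured compounds shown here, no measured step covers such a swap, and the only guide is the limit of > 100000 nM in this assay, at which 2 of the 3 values shown sit. No step beyond the usual scatter is therefore expected. Compound 4 is estimated at 70000 nM, with an expected range of 20000 nM to 100000 nM.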

Compound 4, half-maximal cytotoxic concentration: > 100000 nM
Compound 4: only a limit was reported; the forecaster's own chance of this, stated with the estimate: 60%; middle value at least 1.4-fold (0.15 log units) away from the limit.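

Compound 3 has no number and compound 4 gives only a limit of the assay, so no step can be read between them. The compounds shown leave open what concentration any of them would take to harm the cells, as the values stop at one ceiling: the limit of > 100000 nM in this assay, at which 3 of the 4 values shown sit.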